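The source may report more compounds than this note shows. Statements on the series, on what has been measured and on what is new or still open speak of the compounds shown alone.

Measured compounds in hand:

compound 1, `Cn1cc(-c2n[nH]c3cc(Br)ccc23)cn1`: 950 nM
compound 2, `Cn1cc(-c2n[nH]c3cc(Nc4ccccc4)ccc23)cn1`: 219000 nM
compound 3, `Cn1cc(-c2n[nH]c3ccc(Br)cc23)cn1`: 1540 nM

Three compounds share a bicyclic core carrying the same methylpyrazole. The read-out is an assay on isolated protein for inhibition of tyrosine-protein kinase receptor UFO (Homo sapiens), with a stated time of 1.5 h; a lower number here means a stronger inhibitor, a higher number a weaker inhibitor. Compound 1 and compound 2 differ in one place: anilino in place of bromo on an aromatic carbon. That single exchange gives a 230-fold higher number from compound 1 to compound 2 (2.36 log units; beyond the scatter), a large step in the direction of weaker inhibition. Compound 3 carries the same bromo group as compound 1, but the two cores are built from the same atoms joined differently; the difference between the two cores is not broken down here. In this assay compound 3 gives 1540 nM, and compound 1 gives 950 nM, a pair that lies within the scatter, so no order between them is claimed.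

Compound 4, `Cn1cc(-c2n[nH]c3ccc(Nc4ccccc4)cc23)cn1`, has not yet been measured. It stands to compound 3 as compound 2 stands to compound 1: anilino in place of bromo on an aromatic carbon. The place descriptions of the two exchanges agree word for word, so this is the same change, made on the other core. Among the compounds with values here, with only one measured instance of the exchange, the expectation rests on compound 1 and compound 2 alone: the step of a 230-fold higher number from compound 1 to compound 2 (2.36 log units; beyond the scatter) is taken as the guide, and for compound 4 a step of about a 190-fold higher number from compound 3 to compound 4 (2.29 log units; beyond the scatter) is expected. Within the data shown here, on that basis compound 4 is estimated at 300000 nM in this assay, with a range from 50000 nM to 1500000 nM allowing for the single precedent and the usual scatter. A number this weak may also come back only as a limit of the assay.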

Compound 4, half-maximal inhibitory concentration: 580 nM
Estimate against measurement, compound 4: 520-fold (2.71 log units) above; measured number below the stated range.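

In this assay, anilino in place of bromo gives a 2.7-fold lower number from compound 3 to compound 4 (0.42 log units; beyond the scatter), a modest step towards stronger inhibition, so the change does not carry from one core to the other in either size or direction: the same change on two cores in this assay, a 230-fold higher number (2.36 log units; beyond the scatter) from compound 1 to compound 2 and a 2.7-fold lower number (0.42 log units; beyond the scatter) from compound 3 to compound 4, 610-fold (2.79 log units) apart, beyond the scatter of two such steps

Within the data shown here, in this series, the outcome of the exchange therefore depends on the core that carries it, and a step read on one core is no guide to the step on the other. The result rests on a single pair on each core, so it does not show why the two cores part ways, nor whether the same split would hold for any exchange other than this one.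

Still open, as far as these compounds go, is whether another group on the same aromatic carbon, such as a simple amine, a methoxy group or a carboxylic acid, would follow the steep loss seen on the core of compound 1 or the modest gain seen on the core of compound 3. Also open, from the compounds shown here alone, is whether a substituent on the anilino ring, such as a fluoro or methoxy group, would strengthen inhibition further on the core of compound 4.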